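Piperidine nitrogen: tert-butoxycarbonyl replacing methoxypyrimidinyl

The source may hold more compounds than are shown below. What is called first, only, known or untested is meant among the compounds shown, and "the series" means these compounds.

Measured compounds:
compound 1 `CS(=O)(=O)c1ccc2c(c1)CCN2c1ncnc2c(C3CCN(c4ncccn4)CC3)coc12`: 196%
compound 2 `CC(O)c1cnc(N2CCC(c3coc4c(N5CCc6cc(S(C)(=O)=O)ccc65)ncnc34)CC2)nc1`: 33%
compound 3 `COc1cnc(N2CCC(c3coc4c(N5CCc6cc(S(C)(=O)=O)ccc65)ncnc34)CC2)nc1`: 186%

In a functional assay on cells for agonist activity at Glucose-dependent insulinotropic receptor (Homo sapiens), read by a luciferase reporter, with a stated time of 4 h (a higher number here means a larger maximal response, a lower number a smaller maximal response), compound 3 gives 186%, the second highest of the three numbers. Its nearest neighbour is compound 1, and the step of a number 10 percentage points lower from compound 1 to compound 3 (within the scatter) lies within the scatter. The furthest is compound 2, and the step of a number 153 percentage points higher from compound 2 to compound 3 (beyond the scatter) is large. Compound 4 `CC(C)(C)OC(=O)N1CCC(c2coc3c(N4CCc5cc(S(C)(=O)=O)ccc54)ncnc23)CC1` differs from compound 3 in one place: tert-butoxycarbonyl in place of 5-methoxypyrimidin-2-yl on an amine nitrogen in a ring. The measured steps, a number 163 percentage points lower from compound 1 to compound 2 (beyond the scatter) and the two already named, all exchange a group on an aromatic carbon of the 5-methoxypyrimidin-2-yl group while that group itself stays in place; none of them exchanges the group on the amine nitrogen in the ring, so none bears directly on this change. Neither the direction nor the size of the step can be read from the three measured compounds, and the expectation is correspondingly wide. For compound 4 the expected value is 110%, in the range 30% to 200%. The expected step is a number 76 percentage points lower from compound 3 to compound 4 (beyond the scatter), with a real possibility of a change beyond the scatter in either direction.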

Compound 4, largest response reached (Emax), in percent of the reference or control that the assay uses: 123%
Estimate against measurement, compound 4: 13 percentage points below, and the stated range covers the measured number.
By their numbers in this assay, from the lowest: compound 2; then compound 4; then compounds 3 and 1 (each within the scatter of the next).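

In this assay, a group with no ring on the amine nitrogen in the ring still gives a clear response, but the pyrimidine compounds without the 1-hydroxyethyl group stand apart from it: the steps are a number 63 percentage points lower from compound 3 to compound 4 (beyond the scatter) and a number 73 percentage points lower from compound 1 to compound 4 (beyond the scatter). A pyrimidine on this nitrogen does not by itself give the higher number, as compound 2 goes against that pattern with a number 90 percentage points higher from compound 2 to compound 4 (beyond the scatter), so the substituent on the pyrimidine still decides where such compounds fall relative to tert-butoxycarbonyl. No supporting measurement accounts for these differences.

Going by these compounds, whether a smaller carbamate such as methoxycarbonyl, or an acetyl amide, would fall nearer compound 4 or compound 3 stays open. Also open, on these data alone, is whether an amine or a carboxylic acid on the pyrimidine would follow methoxy or 1-hydroxyethyl.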